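The source may report more compounds than this note shows. Statements on the series, on what has been measured and on what is new or still open speak of the compounds shown alone.

Measured so far:
- compound 1, `CN(C)c1ccc(CN(C)c2nc(=O)c3cc(C(F)(F)F)cc([N+](=O)[O-])c3s2)cc1`, with > 10000 nM in an ADME assay on HEK293 cells (Homo sapiens) for cytotoxicity, read by MTT assay, with a stated time of 24 h; on this read-out higher numbers stand for lower toxicity in this test and lower numbers for higher toxicity in this test
- compound 2, `CN(C(=O)CN1CCN(c2nc(=O)c3cc(C(F)(F)F)cc([N+](=O)[O-])c3s2)CC1)c1ccccc1`, with > 10000 nM in this assay

In this assay compound 1 sits at a limit of the method rather than at a number. For the measured compounds named here, compound 2 likewise gives only a limit in this assay, so it cannot be placed against any number; the one other value shown is a limit too, as the limit of > 10000 nM in this assay, at which 2 of the 2 values shown sit, notes.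

Compound 3, `O=c1nc(N2CCN(c3nccs3)CC2)sc2c([N+](=O)[O-])cc(C(F)(F)F)cc12`, has not been measured. It differs from compound 2 by 1,3-thiazol-2-yl in place of (methyl(phenyl)carbamoyl)methyl on an amine nitrogen in a ring. Going by the values given here, no step between measured compounds is known, and with both measured values at the same limit, no step beyond the scatter is expected; the estimated step that the limit leaves unreadable from compound 2 to compound 3 rests on that. For compound 3 a value of 15000 nM is expected, within 5000 nM to 50000 nM.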

Compound 3, half-maximal cytotoxic concentration: > 10000 nM
Compound 3 gave a limit, no number; the forecaster's own chance of this, stated with the estimate: 80%; the middle value does not contradict the limit.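

Compound 3 also gives only a limit in this assay, so no step separating it from compound 2 can be read: the limit of > 10000 nM in this assay, at which 3 of the 3 values shown sit.

The compounds shown leave open how any of the three ranks against another in this assay.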